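This account rests on a few compounds, and the source may have more. Where it says the series, first, only, none or still open, it means among the compounds named here.

Measured in a functional assay on HEK293 cells (Homo sapiens) for cytotoxicity (a higher number here means that more compound is tolerated, a lower number that less compound is tolerated), with these results:
- Compound 1 `COc1ccc([C@H]2CC(=O)N(Cc3cccc(C#N)c3)C2)cc1OC1CCCC1` gives > 10000 nM as a limit
- Compound 2 `COc1ccc([C@H]2CC(=O)N(c3cc(N)cc(N)c3)C2)cc1OC1CCCC1` gives > 10000 nM as a limit
- Compound 3 `COc1ccc([C@H]2CC(=O)N(c3cccc(C)c3)C2)cc1OC1CCCC1` gives > 10000 nM as a limit

Like the other two, compound 3 stands at the limit of > 10000 nM in this assay, at which 3 of the 3 values shown sit, and so has no exact number. Compound 4 `CCCCNc1cccc(N2C[C@@H](c3ccc(OC)c(OC4CCCC4)c3)CC2=O)c1` carries butylamino in place of methyl on an aromatic carbon and keeps the rest of compound 3 unchanged. The nearest measured changes are a step that the two limits leave unreadable from compound 1 to compound 3 and a step that the two limits leave unreadable from compound 2 to compound 3 and both swap a group on an amide-type nitrogen in a ring. Neither has a readable size, and a step that the two limits leave unreadable from compound 1 to compound 2 adds no size either. The expected change is a step that the limit leaves unreadable from compound 3 to compound 4 and no direction is favoured. The estimate for compound 4 is 15000 nM (expected range 6000 nM to 40000 nM).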

Compound 4, half-maximal cytotoxic concentration: > 10000 nM
Compound 4 ended at the assay's limit; the forecaster's own chance of this, stated with the estimate: 85%; the middle value lies beyond the limit too.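

No step can be read from compound 3 to compound 4, since neither has an exact number and both stand at the same limit: the limit of > 10000 nM in this assay, at which 4 of the 4 values shown sit. The compounds shown leave open what exact value any of them would reach in this assay.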